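The source may report more compounds than this note shows. Statements on the series, on what has been measured and on what is new or still open speak of the compounds shown alone.

Compound 1: `COc1cc2c(Nc3nc4ccc(C(=O)Nc5c(C)cc(C)cc5C)cc4s3)ncnc2cc1OCCCN1CCC(C)CC1` with 6900 nM
Compound 2: `CCN(CC)CCCOc1cc2ncnc(Nc3nc4ccc(C(=O)Nc5c(C)cc(C)cc5C)cc4s3)c2cc1OC` with 7500 nM

In a functional assay on HCT-116 cells (Homo sapiens) for cytotoxicity, read by WST assay, with a stated time of 72 h (on this read-out lower numbers stand for stronger inhibition and higher numbers for weaker inhibition), compound 2 gives 7500 nM, the highest of the two numbers, and compound 1 gives 6900 nM. Going by the values given here, the one measured step, a 1.1-fold higher number from compound 1 to compound 2 (0.04 log units; within the scatter), lies within the scatter. Compound 3 is `COc1cc2c(Nc3nc4ccc(C(=O)Nc5c(C)cc(C)cc5C)cc4s3)ncnc2cc1OCCCN1CCCCC1`; it differs from compound 2 by piperidin-1-yl in place of diethylamino on a saturated chain carbon, three bonds along the chain from an oxygen on an aromatic ring. Among the compounds with values here, the only step that bears on it is a 1.1-fold higher number from compound 1 to compound 2 (0.04 log units; within the scatter), which also swapped one amine for another at this place and changed little, so for compound 3 no step beyond the scatter is expected in this assay: a 1.1-fold lower number from compound 2 to compound 3 (0.03 log units; within the scatter). Compound 3 is therefore estimated at 7000 nM, with a range from 3500 nM to 14000 nM.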

Compound 3, half-maximal inhibitory concentration: 16900 nM
Beside the measured number, compound 3's estimate is 2.4-fold (0.38 log units) below it; the measured number lies above the stated range.
By their numbers in this assay, from the lowest: compounds 1 and 2 (each within the scatter of the next); then compound 3.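

In this assay, the amine at this place can matter after all: piperidin-1-yl in place of diethylamino gives a 2.3-fold higher number from compound 2 to compound 3 (0.35 log units; beyond the scatter), a modest loss beyond the scatter. Hydrogen in place of methyl on a saturated ring carbon gives a 2.4-fold higher number from compound 1 to compound 3 (0.39 log units; beyond the scatter), so this single methyl goes with a step of about the same size, while the change from 4-methylpiperidin-1-yl to diethylamino stayed within the scatter. Nothing available explains either step. Still open, on these data alone, is how a morpholine or a pyrrolidine at this place would compare, and whether either step would hold on a longer chain.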